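The source may report more compounds than this note shows. Statements on the series, on what has been measured and on what is new or still open speak of the compounds shown alone.

Compound 1 `Cc1ccc(Nc2ncc3c(n2)N(Cc2ccccc2)C(=O)N(c2cc(NC(=O)c4ccc(C)c(C(F)(F)F)c4)ccc2C)C3)cn1` stands at the edge of what an ADME assay on BaF3 cells (Mus musculus) for inhibition, read by CellTiter-Glo, with a stated time of 72 h (a higher number here means a weaker inhibitor of growth, a lower number a stronger inhibitor of growth), reports: it gives > 5000 nM, which is a limit of the assay and not a number. Two of the three values shown sit at that limit (the limit of > 5000 nM in this assay, at which 2 of the 3 values shown sit). Compound 3 `Cc1ccc(Nc2ncc3c(n2)N(C)C(=O)N(c2cc(NC(=O)c4cc(-n5cnc(C)c5)cc(C(F)(F)F)c4)ccc2C)C3)cn1` also gives > 5000 nM in this assay, again a limit. Compound 2 `Cc1ccc(NC(=O)c2ccc(CN3CCC(N(C)C)C3)c(C(F)(F)F)c2)cc1N1Cc2cnc(Nc3cnn(C)c3)nc2N(C)C1=O` gives 414 nM in this assay. Compound 4 `CCN1C(=O)N(c2cc(NC(=O)c3ccc(C)c(C(F)(F)F)c3)ccc2C)Cc2cnc(Nc3ccc(C)nc3)nc21` differs from compound 1 in one place: methyl in place of phenyl on a saturated chain carbon bound to an amide-type nitrogen in a ring. Within the data shown here, no measured pair isolates this change, and compound 2 and compound 3 differ from compound 1 in several places at once, so their values give no direct guide. The step that the limit leaves unreadable from compound 1 to compound 4 is expected to be none beyond the scatter. Compound 4 is therefore expected to give 6000 nM, most likely again reported as a limit, within a range of 1500 nM to 20000 nM.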

Compound 4, concentration for 50% growth inhibition: 708 nM
Compound 4: middle estimate off by 8.5-fold (0.93 log units), on the high side; the whole stated range lies above it.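

In this assay compound 1 gives > 5000 nM, a limit of the assay and not a number. Methyl in place of phenyl on a saturated chain carbon bound to an amide-type nitrogen in a ring gives an at least 7.0-fold lower number from compound 1 to compound 4 (0.84 log units; beyond the scatter), so this position does affect growth inhibition, and the benzyl to ethyl change is the first single-place comparison in the series. The full size of the step remains unknown, as its starting point is a limit: the limit of > 5000 nM in this assay, at which 2 of the 4 values shown sit.

From the compounds shown here alone, whether a propyl chain at this place would hold the value of compound 4, 708 nM, remains open. So does the effect of a chain ending in an amine.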